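Oxime ether chain length in the imidazoline aniline series

The source may report more compounds than this note shows. Statements on the series, on what has been measured and on what is new or still open speak of the compounds shown alone.

Measured so far:
compound 1, `c1coc(-c2ccccc2NCC2=NCCN2)c1`: 0.468 nM
compound 2, `CC/C(=N\OC)c1ccccc1NCC1=NCCN1`: 3.31 nM

Both numbers come from a functional assay for activation of Alpha-1A adrenergic receptor (Homo sapiens), read by calcium flux; on this read-out higher numbers stand for an effect only at larger amounts of compound and lower numbers for an effect already at smaller amounts. Among the compounds with values here, compound 2 stands highest of the two; the single measured step, a 7.1-fold higher number from compound 1 to compound 2 (0.85 log units; beyond the scatter), separates it from compound 1. Compound 3, `CO/N=C/c1ccccc1NCC1=NCCN1`, is the next member. Relative to compound 2 the change is a group of 4 heavy atoms (2 carbon, 1 nitrogen, 1 oxygen; no ring) in place of a group of 6 heavy atoms (4 carbon, 1 nitrogen, 1 oxygen; no ring), on an aromatic carbon. Within the data shown here, no measured step covers this kind of change: the one step known, a 7.1-fold higher number from compound 1 to compound 2 (0.85 log units; beyond the scatter), trades a ring for an open chain rather than shortening a chain, so it shows only how far one substituent exchange has moved this series. The step to compound 3 is therefore expected to stay small, estimated as a 1.7-fold lower number from compound 2 to compound 3 (0.22 log units; within the scatter). Compound 3 is expected to give about 2 nM in this assay, within a range from 0.5 nM to 10 nM.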

Compound 3, half-maximal effective concentration: 51.3 nM
Compound 3: the middle estimate sits 26-fold (1.41 log units) below what was measured; the measured number lies above the stated range.
By their numbers in this assay, from the lowest: compound 1; then compound 2; then compound 3.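

In this assay this position proves sensitive to a change that involves no ring: a 15-fold higher number from compound 2 to compound 3 (1.19 log units; beyond the scatter) is large, although the group of 4 heavy atoms that enters matches the group of 6 heavy atoms that leaves in its counts of double bonds, donors and acceptors. Shortening the open chain therefore moves the number well beyond the scatter, and the ring-for-chain exchange is not the only kind of change that matters here. The widest gap in the set is now a 110-fold higher number from compound 1 to compound 3 (2.04 log units; beyond the scatter), and nothing available accounts for the effect of the shortening.

Two open-chain members cannot establish a trend with chain length. From the compounds shown here alone, it remains open whether a methyl group or a propyl chain in place of the ethyl group of compound 2 would give a number that fits one.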